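This account rests on a few compounds, and the source may have more. Where it says the series, first, only, none or still open, it means among the compounds named here.

This piece follows a single change made to compound 1, whose structure is `Cc1ccccc1Nc1ccc2c(c1)C(=O)N(C1CCC(=O)NC1=O)C2=O`. It is a substituted amine built on a shared core, and in an assay on FRT-Jurkat cells for inhibition of nuclear factor NF-kappa-B complex (Homo sapiens), read by flow cytometry, with a stated time of 24 h, tested at 10 uM (a higher number here means more inhibition at the concentration tested (going by the name of the read-out), a lower number less inhibition), compound 1 gives 2%, the lowest of the three numbers measured. Compound 3, with structure `Cc1ccccc1Nc1cccc2c1C(=O)N(C1CCC(=O)NC1=O)C2=O`, carries the same 2-methylphenyl group and differs from compound 1 only in how the amine is joined to the shared core; in this assay compound 3 gives 7%, which is within the scatter of compound 1. Compound 2, with structure `CCCc1ccc(Nc2cccc3c2C(=O)N(C2CCC(=O)NC2=O)C3=O)cc1`, gives 23% in this assay, well above compound 1.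

The new compound, compound 4, has structure `CCCc1ccc(Nc2ccc3c(c2)C(=O)N(C2CCC(=O)NC2=O)C3=O)cc1`. It differs from compound 1 in this way: 4-propylphenyl in place of 2-methylphenyl on a nitrogen on an aromatic ring

For the measured compounds named here, the one measured step that bears on this is the matching exchange in the other attachment, a number 16 percentage points lower from compound 2 to compound 3 (beyond the scatter). Reversing that step suggests a gain of similar size. The step of a number 16 percentage points higher from compound 1 to compound 4 (beyond the scatter) is therefore expected, giving for compound 4 an estimated 18%, expected to fall between 5% and 35%.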

Compound 4, a percentage reported as inhibition, at one concentration (the size of the read-out at that concentration, not a potency): 10%
Beside the measured number, compound 4's estimate is 8 percentage points above it; low and high end bracket the measured number.
By their numbers in this assay, from the lowest: compounds 1, 3 and 4 (each within the scatter of the next); then compound 2.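

In this assay, placing 4-propylphenyl in place of 2-methylphenyl on this attachment of the shared core gives a number 8 percentage points higher from compound 1 to compound 4 (within the scatter), so here the two groups cannot be told apart. The earlier compounds shown here showed this exchange only on the other attachment, where the step lay beyond the scatter, so a clear effect there does not guarantee a clear effect here. Even so, the gap between the two steps is itself small enough that the exchange may behave alike on both attachments: the same change on two cores in this assay, a number 16 percentage points lower (beyond the scatter) from compound 2 to compound 3 and a number 8 percentage points lower (within the scatter) from compound 4 to compound 1, 8 percentage points apart, within the scatter of two such steps

Each compound was read at a single concentration, so these numbers give no potency and leave open how the compounds would rank across a range of concentrations. As far as these compounds go, it also remains open whether a longer chain or a carboxylic acid in place of the propyl chain would move the number on either attachment.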